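The compounds below may be only part of what the source reports. "The series", "measured", "known", "first", "only" and "open" are said of these compounds alone.

Compound 1 `O=c1[nH]nc2n(c1=O)CCN2c1ccccc1` and compound 2 `N=c1c(=O)[nH]nc2n1CCN2c1ccccc1` share a closely related two-ring core carrying a phenyl group, but the difference between the two cores is not broken down here. In a functional assay on A549 cells (Homo sapiens) for antiproliferative activity, with a stated time of 72 h, tested at 10 ug/mL (a lower number here means a weaker effect, a higher number a stronger effect of the compound at the concentration tested), compound 1 gives 0%, and compound 2 gives 7%; the two numbers lie within the usual scatter of each other, so neither can be called the more active. Compound 3 `O=c1[nH]nc2n(c1=O)CCN2c1ccc(Cl)cc1` is derived from compound 1 by a single change: chloro in place of hydrogen on an aromatic carbon. In this assay compound 3 gives 0%, which means no change at the digits printed from compound 1 to compound 3 (within the scatter). Compound 4 `N=c1c(=O)[nH]nc2n1CCN2c1ccc(Cl)cc1` carries the same structural change, made this time on compound 2: chloro in place of hydrogen on an aromatic carbon. Because no change at the digits printed from compound 1 to compound 3 (within the scatter) was measured as no change when this chloro was introduced onto compound 1, the expected step in this assay is a number 2 percentage points lower from compound 2 to compound 4 (within the scatter), a step of about the same small size as the earlier one. On that basis compound 4 is estimated at 5%, with a likely range from 0% to 15%.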

Compound 4, a percentage reported as inhibition, at one concentration (the size of the read-out at that concentration, not a potency): 25%
Compound 4: the middle estimate sits 20 percentage points below what was measured; measured number outside the range, above it.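

In this assay, chloro in place of hydrogen on the aromatic ring gives a number 18 percentage points higher from compound 2 to compound 4 (beyond the scatter). The same change therefore does not give the same step on the two cores: the same change on two cores in this assay, no change at the digits printed (within the scatter) from compound 1 to compound 3 and a number 18 percentage points higher (beyond the scatter) from compound 2 to compound 4, 18 percentage points apart, beyond the scatter of two such steps

Among the compounds shown here, this shows that, for this pair of cores, the step seen on one core was a poor guide to the step on the other, but it rests on only two steps and does not explain why they differ or predict what chloro would do on a further core; compound 4, at 25%, also has only a reading at a single concentration, which is not a potency.

From the compounds shown here alone, it remains open whether the larger step on the core of compound 2 is particular to chloro or would also appear with another group in the same place, such as fluoro, methoxy or an amine. Going by these compounds, how compound 4 would read at other concentrations also remains open.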